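Urea series: cyanobenzyl to dimethoxybenzyl swap

The source may hold more compounds than are shown below. What is called first, only, known or untested is meant among the compounds shown, and "the series" means these compounds.

Measured compounds:
compound 1 `COc1ccc(CN(C(=O)Nc2ccc(C#N)cc2)n2cnnc2)cc1OC` — in a functional assay on MDA-MB-231 cells (Homo sapiens) for cytotoxicity, read by MTT assay, with a stated time of 48 h (on this read-out lower numbers stand for stronger inhibition and higher numbers for weaker inhibition), compound 1 gives > 50000 nM, a limit of the assay rather than a number.
compound 2 `N#Cc1ccc(CN(C(=O)Nc2cc(C(F)(F)F)cc(C(F)(F)F)c2)n2cnnc2)cc1` — in this assay compound 2 gives 9280 nM.

Compound 2 therefore stands as the only numerical result in this assay; the other value shown is a limit. Compound 1 sits at the limit of > 50000 nM in this assay, at which 1 of the 2 values shown sits.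

Compound 3 `COc1ccc(CN(C(=O)Nc2cc(C(F)(F)F)cc(C(F)(F)F)c2)n2cnnc2)cc1OC` remains to be measured. It differs from compound 2 by 3,4-dimethoxyphenyl in place of 4-cyanophenyl on a saturated chain carbon bound to an amide-type nitrogen. Within the data shown here, no measured pair differs in one place only, so the size of this step cannot be read from the data directly. Compound 1 already carries the 3,4-dimethoxybenzyl and sits at the limit of > 50000 nM in this assay, at which 1 of the 2 values shown sits, whereas compound 2 with the 4-cyanobenzyl gives 9280 nM; these two compounds also differ in a second place, so the comparison does not isolate the benzyl change.

The step from compound 2 to compound 3 is expected to be beyond the scatter and toward weaker inhibition, with a real chance that only a limit is returned. Compound 3 is estimated at 25000 nM, with a range from 8000 nM to 80000 nM. This corresponds to an expected step of a 2.7-fold higher number from compound 2 to compound 3 (0.43 log units; beyond the scatter).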

Compound 3, half-maximal inhibitory concentration: 25300 nM
Compound 3: the middle estimate sits 1.0-fold (0.01 log units) below what was measured, within the range that was stated.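

On a saturated chain carbon bound to an amide-type nitrogen, the change from 4-cyanobenzyl to 3,4-dimethoxybenzyl can now be read on its own in this assay, with the rest of the molecule held constant (a 2.7-fold higher number from compound 2 to compound 3 (0.44 log units; beyond the scatter)). The position is therefore sensitive to this exchange, and the direction is toward weaker inhibition, although with the rest of the molecule of compound 2 the 3,4-dimethoxybenzyl still returns a number, as compound 3 gives 25300 nM in this assay. Compound 1, which carries the same 3,4-dimethoxybenzyl, remains a limit of the assay and not a number: the limit of > 50000 nM in this assay, at which 1 of the 3 values shown sits.

As far as these compounds go, the step between compound 1 and compound 3 cannot be read, so the size of the effect of the other place in which they differ remains open. Also open, from the compounds shown here alone, is how this position responds to other groups, for instance an unsubstituted benzyl, a 4-methoxybenzyl carrying a single methoxy, or a longer chain such as 2-phenylethyl, and whether any of these falls closer to compound 2 or to compound 3.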